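Swapping Chloro for Nitro: What Compound 4 Might Tolerate

A few compounds are considered here, and "the series" means these few. Any claim that something is new, unique, unknown or untested is made for them only; others in the source may bear on it.

Three compounds have been measured in an ADME assay on Vero cells (Chlorocebus sabaeus) for cytotoxicity, read by MTT assay, with a stated time of 72 h; a lower number here means that less compound is tolerated, a higher number that more compound is tolerated:
Compound 1 `S=C(N/N=C\c1ccc(Cl)cc1)N(Cc1ccccc1)Cc1ccccc1` gives 159000 nM.
Compound 2 `O=[N+]([O-])c1ccc(/C=N\NC(=S)N(Cc2ccccc2)Cc2ccccc2)cc1` gives only a limit of the assay, < 155000 nM.
Compound 3 `C=CCN(CC=C)C(=S)N/N=C\c1ccc(Cl)cc1` gives 213000 nM.

Compound 2 differs from compound 1 by nitro in place of chloro on an aromatic carbon. The step this change made is an at least 1.0-fold lower number from compound 1 to compound 2 (0.01 log units; that floor lies within the scatter). That step rests on (the limit of < 155000 nM in this assay, at which 1 of the 3 values shown sits), so it is a floor rather than a measured distance. The difference between the core of compound 1 and the core of compound 3 is not broken down here. Compound 3 holds the highest of the two numbers, with compound 1 nearest, and the two lie within the usual scatter of each other, so no order between them is claimed.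

Compound 4 `C=CCN(CC=C)C(=S)N/N=C\c1ccc([N+](=O)[O-])cc1` has not yet been measured. It differs from compound 3 by nitro in place of chloro on an aromatic carbon, and this is the same change, at the same place, as that from compound 1 to compound 2. From compound 3 the expected step is a 1.3-fold lower number from compound 3 to compound 4 (0.10 log units; within the scatter), which rests on the measured step of an at least 1.0-fold lower number from compound 1 to compound 2 (0.01 log units; that floor lies within the scatter) and on the value of compound 3 in this assay . Because compound 2 reached (the limit of < 155000 nM in this assay, at which 1 of the 3 values shown sits), compound 4 may likewise be reported only as a limit. For compound 4 the estimate is 170000 nM, expected to fall between 110000 nM and 280000 nM.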

Compound 4, half-maximal cytotoxic concentration: < 206000 nM
Compound 4 was reported as a limit; the forecaster's own chance of this, stated with the estimate: 30%; the middle value does not contradict the limit.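

In this assay, nitro in place of chloro on an aromatic carbon of the core of compound 3 gives an at least 1.0-fold lower number from compound 3 to compound 4 (0.01 log units; that floor lies within the scatter), and this step is a floor rather than a measured distance. Set beside the earlier step, the change ends at a limit of the assay on both cores, so nothing here speaks against its carrying over from one core to the other: the same change on two cores in this assay, an at least 1.0-fold lower number (0.01 log units; that floor lies within the scatter) from compound 1 to compound 2 and an at least 1.0-fold lower number (0.01 log units; that floor lies within the scatter) from compound 3 to compound 4; the limit leaves it open whether they differ What this does not show is how large the change is on either core, since neither compound 2 nor compound 4 has a measured number and neither floor lies beyond the scatter, so no drop in the number is established on either core.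

The compounds shown carry only chloro or nitro at this place, on two cores, so they leave open how an amine or a carboxylic acid there would read in this assay. They also leave open whether the change would end the same way on a core with a longer chain, and whether a read-out with a measured number for the nitro compounds would separate the two cores at all.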